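A Ring Replaces the Open Chain on the Shared Core

The source may report more compounds than this note shows. Statements on the series, on what has been measured and on what is new or still open speak of the compounds shown alone.

In a functional assay on MCF7 cells (Homo sapiens) for inhibition, read by fluorescence, with a stated time of 72 h (on this read-out lower numbers stand for stronger inhibition and higher numbers for weaker inhibition), compound 1 (`CC(C)n1cnc2c(NC(=N)N)nc(NCCO)nc21`) gives 12400 nM. Compound 2 (`CC[C@@H](N)COc1nc(NC(=N)N)c2ncn(C(C)C)c2n1`) reads > 100000 nM, which is a limit of the assay and not a number. Compound 3 (`CC(C)[C@@H](N)COc1nc(NC(=N)N)c2ncn(C(C)C)c2n1`) gives 79400 nM, the higher of the two values reported as actual numbers, and compound 1 is its nearest neighbour.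

The next structure, compound 4 (`CC(C)n1cnc2c(NC(=N)N)nc(N3CCC[C@H]3CO)nc21`), exchanges the side chain of compound 3 on the aromatic carbon between two ring nitrogen atoms: 2-(hydroxymethyl)pyrrolidin-1-yl in place of 2-amino-3-methylbutoxy on an aromatic carbon. 2-(hydroxymethyl)pyrrolidin-1-yl enters in place of 2-amino-3-methylbutoxy.

The most relevant evidence is the exchange of (2-hydroxyethyl)amino for the outgoing group, which gave a 6.4-fold higher number from compound 1 to compound 3 (0.81 log units; beyond the scatter). The 2-aminobutoxy exchange points the same way, with an at least 8.0-fold higher number from compound 1 to compound 2 (0.90 log units; beyond the scatter). The methyl difference, an at least 1.2-fold lower number from compound 2 to compound 3 (0.10 log units; that floor lies within the scatter), adds little. For the measured compounds named here, the entering group resembles the (2-hydroxyethyl)amino of compound 1 more closely than it resembles the group that leaves, so a move back toward 12400 nM seems likely, though probably not all the way, since the ring has no measured precedent here.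

The expected change is a 3.2-fold lower number from compound 3 to compound 4 (0.50 log units; beyond the scatter), a modest step toward stronger inhibition. For compound 4 the estimated value is 25000 nM, with an expected range from 7000 nM to 90000 nM.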

Compound 4, half-maximal inhibitory concentration: 6200 nM
For compound 4 the middle estimate is 4.0-fold (0.61 log units) above the measured one; the whole stated range lies above it.
By their numbers in this assay, from the lowest: compounds 4 and 1 (each within the scatter of the next); then compound 3. At a limit, above all of these: compound 2.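

In this assay, the exchange on the aromatic carbon between two ring nitrogen atoms gives a 13-fold lower number from compound 3 to compound 4 (1.11 log units; beyond the scatter) even though the leaving and entering groups have the same counts of heavy atoms, hydrogen-bond donors and hydrogen-bond acceptors, so those counts alone do not set the read-out at this position. The step of a 2.0-fold lower number from compound 1 to compound 4 (0.30 log units; within the scatter) lies within the scatter, which means the ring of compound 4 and the open (2-hydroxyethyl)amino chain of compound 1 cannot be told apart here, and among the four compounds the two groups joined through nitrogen and bearing a hydroxyl both sit clear of the two joined through oxygen. The step of an at least 16-fold lower number from compound 2 to compound 4 (1.20 log units; beyond the scatter) agrees with this, but compound 2 stands at a limit of the assay and not at a number: the limit of > 100000 nM in this assay, at which 1 of the 4 values shown sits.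

The compounds shown leave open whether the link through nitrogen, the ring or the hydroxyl carries the change, as these differ together between compound 3 and compound 4. A plain pyrrolidin-1-yl group, or a piperidine ring carrying the same hydroxymethyl, would begin to separate them.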